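The source may hold more compounds than are shown below. What is called first, only, known or untested is meant among the compounds shown, and "the series" means these compounds.

Measured so far in a toxicity assay on MT2 cells (Homo sapiens) for cytotoxicity, read by XTT assay, with a stated time of 4 days; a lower number here means that less compound is tolerated, a higher number that more compound is tolerated:

- compound 1 `Cc1nc(C)c([C@H](OC(C)(C)C)C(=O)O)c(N2CCC(C)(C)CC2)c1-c1ccc(-c2ccccc2)cc1`: in this assay compound 1 gives >= 20000 nM, a limit of the assay.
- compound 2 `Cc1nc(C)c([C@H](OC(C)(C)C)C(=O)O)c(N2CCC(C)(C)CC2)c1-c1ccc(Oc2ccccc2)cc1`: in this assay compound 2 gives >= 20000 nM, again a limit.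
- compound 3 `Cc1nc(C)c([C@H](OC(C)(C)C)C(=O)O)c(N2CCC(C)(C)CC2)c1-c1ccc(SCCc2ccc(F)cc2)cc1`: in this assay compound 3 gives >= 32000 nM, also a limit.

Compound 2 thus stands at a limit, not at a number, and so do the two other values shown the limit of >= 20000 nM in this assay, at which 2 of the 3 values shown sit (the limit of >= 32000 nM in this assay, at which 1 of the 3 values shown sits). Compound 4 `Cc1ncsc1CCOc1ccc(-c2c(C)nc(C)c([C@H](OC(C)(C)C)C(=O)O)c2N2CCC(C)(C)CC2)cc1` differs from compound 2 by 2-(4-methyl-1,3-thiazol-5-yl)ethyl in place of phenyl on an oxygen on an aromatic ring.

The measured steps that touch this position are all unreadable: a step that the two limits leave unreadable from compound 1 to compound 2, a step that the two limits leave unreadable from compound 2 to compound 3 and a step that the two limits leave unreadable from compound 1 to compound 3. None of them gives a size, since both ends sit at limits. Three different groups on this aromatic carbon, phenyl, phenoxy and (2-(4-fluorophenyl)ethyl)sulfanyl, all leave the compound tolerated up to the limit.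

Expected step a number no higher from compound 2 to compound 4 (the limit leaves the size open): none beyond the scatter, with the result again most likely a limit. Compound 4 is therefore estimated at 20000 nM, range 10000 nM to 40000 nM.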

Compound 4, half-maximal cytotoxic concentration: >= 25000 nM
Compound 4 was reported as a limit (the forecaster's own chance of this, stated with the estimate: 85%); at least 1.2-fold (0.09 log units) between middle value and limit.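

In this assay compound 4 gives >= 25000 nM, a limit of the assay. Its steps from compound 1, compound 2 and compound 3 cannot be read, since both ends of each are limits. The compounds shown leave open at what concentration any of them becomes cytotoxic, and whether the groups compared differ at all.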